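The source may report more compounds than this note shows. Statements on the series, on what has been measured and on what is new or still open speak of the compounds shown alone.

Compound 2 `COc1ccc(-c2nc(C)c(C(=O)CSc3nc(-c4ccc(OC)cc4)c(C#N)c(=O)[nH]3)s2)cc1` carries the lowest number of the three measured compounds in a functional assay on U-87MG ATCC cells for antiproliferative activity against U-87 MG (Homo sapiens), read by MTT assay, with a stated time of 48 h, tested at 50 uM; a lower number here means a stronger effect, a higher number a weaker effect of the compound at the concentration tested: compound 2 gives 32.6%. Its nearest neighbour is compound 3 `COc1ccc(-c2nc(C)c(C(=O)CSc3nc(-c4cccc(OC)c4)c(C#N)c(=O)[nH]3)s2)cc1`, which in this assay gives 43.2%, and the furthest is compound 1 `COc1ccc(-c2nc(C)c(C(=O)CSc3nc(-c4ccc(Cl)cc4)c(C#N)c(=O)[nH]3)s2)cc1`, which gives 48%. The steps among them are a number 15.4 percentage points lower from compound 1 to compound 2 (beyond the scatter), a number 4.8 percentage points lower from compound 1 to compound 3 (within the scatter) and a number 10.6 percentage points higher from compound 2 to compound 3 (beyond the scatter).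

Compound 4 `COc1ccc(-c2nc(SCC(=O)c3sc(-c4ccc(Cl)cc4)nc3C)[nH]c(=O)c2C#N)cc1` differs from compound 2 by chloro in place of methoxy on an aromatic carbon, para to a large group on a six-membered aromatic ring of carbon only. Going by the values given here, the one measured step of the same kind, run the other way, is a number 15.4 percentage points lower from compound 1 to compound 2 (beyond the scatter), although that exchange sat at a different place in the shared core. Reversing it points towards a higher number for compound 4, of a size that is modest and probably close to the measured step. Compound 4 is therefore expected to give 45% in this assay, within a range from 33% to 58%, meaning an estimated step of a number 12.4 percentage points higher from compound 2 to compound 4 (beyond the scatter).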

Compound 4, a percentage reported as activity, at one concentration (the size of the read-out at that concentration, not a potency): 46.3%
Compound 4: the middle estimate sits 1.3 percentage points below what was measured; measured number inside the range.
By their numbers in this assay, from the lowest: compound 2; then compounds 3, 4 and 1 (each within the scatter of the next).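

Compound 4 shows that the position para to a large group on the other aryl ring of the shared core also responds to this exchange: in this assay, chloro in place of methoxy gives a higher number (a number 13.7 percentage points higher from compound 2 to compound 4 (beyond the scatter)). Until now the exchange had been seen only at the first aryl position, in the opposite direction (a number 15.4 percentage points lower from compound 1 to compound 2 (beyond the scatter)). Both steps lie beyond the scatter, so among compounds 1, 2 and 4, the compound with methoxy at both places carries the lowest number. Nothing available here bears on why the number moves with this exchange.

The compounds shown leave open how an amine or a hydroxyl group at this carbon would read. They also leave open how a 3-methoxyphenyl group would read here, or chloro at both places.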